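Methyl scan on the pendant phenyl of two aryl-amide cores

The compounds below may be only part of what the source reports. "The series", "measured", "known", "first", "only" and "open" are said of these compounds alone.

Compound 1 `COc1cc2c(Oc3ccc(NC(=O)c4cc(-c5ccccc5)ccn4)cc3F)ccnc2cc1OCCCN1CCN(C)CC1` is the reference; in a functional assay on HT-29 cells (Homo sapiens) for cytotoxicity, read by MTT assay, with a stated time of 72 h (on this read-out lower numbers stand for stronger inhibition and higher numbers for weaker inhibition), compound 1 gives 82 nM. Compound 2 `COc1cc2c(Oc3ccc(NC(=O)c4cc(-c5ccccc5C)ccn4)cc3F)ccnc2cc1OCCCN1CCN(C)CC1` carries methyl in place of hydrogen on an aromatic carbon, and in this assay compound 2 gives 180 nM, which is a 2.2-fold higher number from compound 1 to compound 2 (0.34 log units; beyond the scatter). Compound 3 `COc1cc2c(Oc3ccc(NC(=O)c4nccc(-c5ccccc5)n4)cc3F)ccnc2cc1OCCCN1CCCCC1` belongs to a second core; the difference between the two cores is not broken down here. In this assay compound 3 gives 260 nM, and against compound 2 its number lies within the scatter, while against compound 1 it is higher and beyond the scatter.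

Compound 4 `COc1cc2c(Oc3ccc(NC(=O)c4nccc(-c5ccc(C)cc5)n4)cc3F)ccnc2cc1OCCCN1CCCCC1` is unmeasured and differs from compound 3 by methyl in place of hydrogen on an aromatic carbon. This is the same kind of change as the step from compound 1 to compound 2, but not the same: there the methyl entered ortho to a large group, here it enters para to a large group, and the core is different.

Among the compounds with values here, compound 4 is expected to give 400 nM in this assay, somewhere between 150 nM and 1000 nM, so an estimated step of a 1.5-fold higher number from compound 3 to compound 4 (0.19 log units; within the scatter), resting on the only measured precedent, the step from compound 1 to compound 2 of a 2.2-fold higher number from compound 1 to compound 2 (0.34 log units; beyond the scatter), weighted toward the smaller end since the position and core differ.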

Compound 4, half-maximal inhibitory concentration: 620 nM
For compound 4 the middle estimate is 1.6-fold (0.19 log units) below the measured one; the range from low to high includes it.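

Methyl in place of hydrogen on the pendant phenyl gives a 2.4-fold higher number from compound 3 to compound 4 (0.38 log units; beyond the scatter) in this assay on the second core, and this step matches the one on the core of compound 1 in size: the same change on two cores in this assay, a 2.2-fold higher number (0.34 log units; beyond the scatter) from compound 1 to compound 2 and a 2.4-fold higher number (0.38 log units; beyond the scatter) from compound 3 to compound 4, 1.1-fold (0.04 log units) apart, within the scatter of two such steps. In these two cores, the change therefore moves the number in the same direction and by a similar amount, although the methyl of compound 4 sits para to a large group and the methyl of compound 2 sits elsewhere on the phenyl. Position and core change together across these two steps, so they do not separate the two factors, and two steps do not show that the result would hold on a further core.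

From the compounds shown here alone, it remains open whether a methyl para to a large group on the core of compound 1 would give a step of the same size. Also open, going by these compounds, is how a methoxy group, a chlorine atom or an amine in place of the methyl would behave on either core.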